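Bromo in Place of Chloro: What to Expect for Compound 4

The compounds below may be only part of what the source reports. "The series", "measured", "known", "first", "only" and "open" are said of these compounds alone.

Measured so far:
compound 1 `COc1ccc(O)c(/C=C/C(=O)c2ccc(Cl)cc2)c1`: 29.3%
compound 2 `Cc1ccc(C(=O)/C=C/c2cc(F)cc(F)c2O)cc1`: 35.3%
compound 3 `COC(=O)C1=C(N)Oc2c(OC)cc(Br)cc2C1CC(=O)c1ccc(Cl)cc1`: 33.8%

All three were tested in a functional assay on MCF7 cells (Homo sapiens) for antiproliferative activity, read by sulforhodamine B assay, with a stated time of 72 h, tested at 30 uM; on this read-out lower numbers stand for a stronger effect and higher numbers for a weaker effect at the one concentration tested. On these numbers compound 3 stands second highest of the three. Its nearest neighbour is compound 2, whose value lies within the usual scatter of compound 3, and its furthest is compound 1, whose value also lies within that scatter. The three measured compounds therefore cannot be told apart on this read-out; none can be called stronger or weaker than another.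

Compound 4 `COC(=O)C1=C(N)Oc2c(OC)cc(Br)cc2C1CC(=O)c1ccc(Br)cc1` has not yet been measured. It differs from compound 3 in a single place: bromo in place of chloro on an aromatic carbon. One halogen takes the place of another on the same aromatic carbon, and nothing else in the structure moves.

Going by the values given here, no step between two measured compounds of this kind is available, so the expectation rests on the change alone. Since it is so small, no step beyond the scatter is expected in this assay; the expected step is a number 0.8 percentage points lower from compound 3 to compound 4 (within the scatter), in effect none. Compound 4 is therefore expected to give about 33%, with a likely range from 22% to 45%.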

Compound 4, a percentage reported as activity, at one concentration (the size of the read-out at that concentration, not a potency): 31.9%
Compound 4: middle estimate off by 1.1 percentage points, on the high side; measured number inside the range.
By their numbers in this assay, from the lowest: compounds 1, 4, 3 and 2 (each within the scatter of the next).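

Going by these compounds alone, compound 3 and compound 4 are the only pair here that differ in one place, so they give the first direct reading of a single change in this assay: 4-chlorophenyl to 4-bromophenyl gives a number 1.9 percentage points lower from compound 3 to compound 4 (within the scatter) in this series. At this position, on an aromatic carbon para to a large group, bromo in place of chloro therefore gives two compounds that cannot be told apart on this read-out. Nothing measured on these two groups is at hand to explain the size of this step.

From the compounds shown here alone, a swap of one halogen for another says little about a very different group here, so whether an amine or a carboxylic acid at this position would give a step beyond the scatter stays open. Each value also comes from one concentration, so how compound 3 and compound 4 compare at other concentrations is open too.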